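Pyridin-2-yl removed from an ether side chain

A few compounds are considered here, and "the series" means these few. Any claim that something is new, unique, unknown or untested is made for them only; others in the source may bear on it.

Compound 1 `O=C(O)CCn1c(=O)oc2cc(OCc3ccccc3)c(Cl)cc21` gives 25.1 nM in an assay for inhibition of kynurenine 3-monooxygenase (Homo sapiens), read by mass spectrometry, with a stated time of 1 h; on this read-out lower numbers stand for stronger inhibition and higher numbers for weaker inhibition.
Compound 2 `O=C(O)CCn1c(=O)oc2cc(OCc3ccccn3)c(Cl)cc21` gives 3.16 nM in this assay.

Compound 2 stands lowest of the two measured numbers, with compound 1 nearest. Among the measured compounds shown here, the one measured step, a 7.9-fold lower number from compound 1 to compound 2 (0.90 log units; beyond the scatter), came from exchanging the aryl group on the side chain. Compound 3 `COc1cc2oc(=O)n(CCC(=O)O)c2cc1Cl` goes further: hydrogen in place of pyridin-2-yl on a saturated chain carbon bound to an oxygen on an aromatic ring. For the measured compounds named here, no measured step removes the aryl group outright, so that step bears only loosely. Even compound 1, which keeps a phenyl, gives 25.1 nM, well above compound 2. Compound 3 is therefore expected to lose clearly: a 95-fold higher number from compound 2 to compound 3 (1.98 log units; beyond the scatter). Compound 3 is estimated at 300 nM, within 50 nM to 3000 nM.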

Compound 3, half-maximal inhibitory concentration: 12.6 nM
Compound 3: middle estimate off by 24-fold (1.38 log units), on the high side; measured number below the stated range.
By their numbers in this assay, from the lowest: compound 2; then compounds 3 and 1 (each within the scatter of the next).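

Losing the aryl group outright costs far less at this position than the earlier compounds suggested, and going from (pyridin-2-yl)methoxy to methoxy gives only a modest step (a 4.0-fold higher number from compound 2 to compound 3 (0.60 log units; beyond the scatter)). The phenyl ether and the methoxy compound cannot be told apart (a 2.0-fold lower number from compound 1 to compound 3 (0.30 log units; within the scatter)), so among these three side chains only the pyridin-2-yl one stands apart. Nothing available explains this result.

Still open, as far as these compounds go, is how a longer chain such as ethoxy, or an amine on the side chain, would read at this place.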